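The source may hold more compounds than are shown below. What is called first, only, known or untested is meant among the compounds shown, and "the series" means these compounds.

In an ADME assay on a cell-free system (plasma, Homo sapiens) for metabolic stability, read by LC-MS, tested at 10 ug/mL (on this read-out higher numbers stand for a longer-lived compound and lower numbers for a shorter-lived compound), three close relatives have been measured so far. Compound 1 `CCNC(=O)c1cc(N)c(Nc2ccc(C#N)cc2)cc1Oc1c(C)cc(/C=C/C#N)cc1C` gives 91 h. Compound 2 `Cc1cc(/C=C/C#N)cc(C)c1Oc1cc(Nc2ccc(C#N)cc2)c(N)cc1C(=O)NCCC(F)F` gives 57 h, and compound 3 `Cc1cc(/C=C/C#N)cc(C)c1Oc1cc(Nc2ccc(C#N)cc2)c(N)cc1C(=O)OCCC#N` gives 32 h. Compound 3 thus sits below compound 1 by a margin beyond the scatter, while its gap to compound 2 lies within the scatter, so those two cannot be told apart here. Compound 4 `CNC(=O)c1cc(N)c(Nc2ccc(C#N)cc2)cc1Oc1c(C)cc(/C=C/C#N)cc1C` has not yet been measured; it differs from compound 3 in one place: methylamino in place of 2-cyanoethoxy on a carbonyl carbon. Within the data shown here, two measured steps bear on this change. The step of a 2.8-fold lower number from compound 1 to compound 3 (0.45 log units; beyond the scatter) swapped ethylamino for 2-cyanoethoxy on the carbonyl carbon, and the step of a 1.8-fold lower number from compound 2 to compound 3 (0.25 log units; within the scatter) swapped (3,3-difluoropropyl)amino for the same 2-cyanoethoxy. The change to compound 4 runs the opposite way, from 2-cyanoethoxy back to a small amino group, so a rise of roughly the size of those steps is expected, bringing compound 4 close to compound 1. The expected step is a 2.5-fold higher number from compound 3 to compound 4 (0.40 log units; beyond the scatter). Compound 4 is therefore estimated at 80 h, within a range from 40 h to 160 h.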

Compound 4, half-life in the plasma assay: 72 h
For compound 4 the middle estimate is 1.1-fold (0.05 log units) above the measured one, and the stated range covers the measured number.
By their numbers in the plasma assay, from the lowest: compounds 3, 2, 4 and 1 (each within the scatter of the next, the first and the last beyond it).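

In the plasma assay, putting methylamino on the carbonyl carbon in place of 2-cyanoethoxy gives a 2.3-fold higher number from compound 3 to compound 4 (0.35 log units; beyond the scatter), so a second compound now stands clear of compound 3, although compound 2 still does not. The chain on the amide nitrogen differs in two further steps, a 1.3-fold higher number from compound 2 to compound 4 (0.10 log units; within the scatter) and a 1.3-fold lower number from compound 1 to compound 4 (0.10 log units; within the scatter). Compound 1, compound 2 and compound 4 cannot be told apart here. In a physicochemical assay for lipophilicity, read by HPLC, measured as octanol-water partition, with a stated time of 24 h, at pH 7.4 (on this read-out higher numbers stand for higher lipophilicity and lower numbers for lower lipophilicity), compound 3 gives > 5, which is a limit of the assay. In the physicochemical assay compound 4 gives 2.65. The change from 2-cyanoethoxy to methylamino thus also goes with a much lower number in the physicochemical assay: the measured partition coefficient of compound 3, > 5, and of compound 4, 2.65, a number at least 2.35 log units lower (beyond the scatter)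

A plain ethoxy group on the same carbonyl carbon could separate the effect of the oxygen link from that of the nitrile in 2-cyanoethoxy. From the compounds shown here alone, whether half-life tracks partition coefficient stays open, as only compound 3 and compound 4 have values for both.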